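A few compounds are considered here, and "the series" means these few. Any claim that something is new, unique, unknown or untested is made for them only; others in the source may bear on it.

In a functional assay on A549 cells (Homo sapiens) for inhibition, read by MTT assay, with a stated time of 72 h (on this read-out higher numbers stand for weaker inhibition and lower numbers for stronger inhibition), three compounds with a shared core have been measured: compound 1 (`Cc1cc2occ(-c3nc(-c4ccccc4)c(-c4ccccc4)n3-c3ccc([N+](=O)[O-])cc3)c(=O)c2cc1Cl`) gives 3130 nM, compound 2 (`Cc1cc2occ(-c3nc(-c4ccccc4)c(-c4ccccc4)n3-c3ccc(Cl)cc3)c(=O)c2cc1Cl`) gives 12500 nM, and compound 3 (`Cc1cc2occ(-c3nc(-c4ccccc4)c(-c4ccccc4)n3-c3cccc([N+](=O)[O-])c3)c(=O)c2cc1Cl`) gives 6250 nM. Compound 3 holds the middle place of these three numbers, but it is not clearly separated from either of the others: the data show a 2.0-fold higher number from compound 1 to compound 3 (0.30 log units; within the scatter) and a 2.0-fold lower number from compound 2 to compound 3 (0.30 log units; within the scatter). Compound 4 (`Cc1cc2occ(-c3nc(-c4ccccc4)c(-c4ccccc4)n3-c3cccc(Cl)c3)c(=O)c2cc1Cl`) has not yet been measured. It differs from compound 3 by chloro in place of nitro on an aromatic carbon, which is chloro in place of nitro on an aromatic carbon, meta to a large group. For the measured compounds named here, the only measured step with this same exchange is a 4.0-fold higher number from compound 1 to compound 2 (0.60 log units; beyond the scatter). That is a single example, on a different compound, so it offers only loose guidance. A modest rise in the number, meaning weaker inhibition, is therefore expected in this assay. The expected size is a 2.4-fold higher number from compound 3 to compound 4 (0.38 log units; beyond the scatter). The estimate for compound 4 is 15000 nM, with an expected range from 7000 nM to 35000 nM.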

Compound 4, half-maximal inhibitory concentration: 25000 nM
Beside the measured number, compound 4's estimate is 1.7-fold (0.22 log units) below it, within the range that was stated.
By their numbers in this assay, from the lowest: compounds 1, 3, 2 and 4 (each within the scatter of the next, the first and the last beyond it).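

Chloro in place of nitro now has a second example in this assay, and a 4.0-fold higher number from compound 3 to compound 4 (0.60 log units; beyond the scatter) matches the earlier step, so the change has the same size with the group as 3-nitrophenyl as with 4-nitrophenyl: the same change on two cores in this assay, a 4.0-fold higher number (0.60 log units; beyond the scatter) from compound 1 to compound 2 and a 4.0-fold higher number (0.60 log units; beyond the scatter) from compound 3 to compound 4, 1.0-fold (0.00 log units) apart, within the scatter of two such steps The chloro pair stays close, since 3-chlorophenyl in place of 4-chlorophenyl gives a 2.0-fold higher number from compound 2 to compound 4 (0.30 log units; within the scatter), just as the two nitro compounds stay within the scatter of each other. The widest gap in the set is an 8.0-fold higher number from compound 1 to compound 4 (0.90 log units; beyond the scatter), so in each matched pair nitro goes with the stronger inhibition, although compound 3 and compound 2 are not separated.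

On these data alone, whether an amine, a methoxy group or a carboxylic acid in either place would read like nitro, like chloro or like neither stays open. The compounds shown also do not tell why this change has the size it has.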